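Methoxy to hydroxy on the chlorophenyl arm

A few compounds are considered here, and "the series" means these few. Any claim that something is new, unique, unknown or untested is made for them only; others in the source may bear on it.

Measured so far:
compound 1 `O=C(Nc1cccc(-n2cc(-c3ccncc3)c(-c3ccc(Cl)c(O)c3)n2)c1)Nc1cccc(C(F)(F)F)c1` — 6510 nM
compound 2 `COc1cc(-c2nn(-c3cccc(NC(=O)Nc4cc(C(F)(F)F)cc(C(F)(F)F)c4)c3)cc2-c2ccncc2)ccc1Cl` — 1210 nM

In a functional assay on BT-549 cells (Homo sapiens) for inhibition, read by sulforhodamine B assay, with a stated time of 48 h (on this read-out lower numbers stand for stronger inhibition of growth and higher numbers for weaker inhibition of growth), compound 2 gives the lowest of the two numbers; compound 1 stands a step beyond the scatter above it. Compound 3 `O=C(Nc1cccc(-n2cc(-c3ccncc3)c(-c3ccc(Cl)c(O)c3)n2)c1)Nc1cc(C(F)(F)F)cc(C(F)(F)F)c1` is the next member: it keeps everything of compound 2 except (hydrogen in place of methyl on an oxygen on an aromatic ring). For the measured compounds named here, compound 1 also carries the 4-chloro-3-hydroxyphenyl, but it differs from compound 3 elsewhere too, and no single-point step is available for that pair, so it gives no direct guide. Going by the values given here, with no measured step for this change, the expectation is a small drift only, and the expected step is a 1.5-fold higher number from compound 2 to compound 3 (0.17 log units; within the scatter), not clearly beyond the scatter in either direction. Compound 3 is therefore estimated at 1800 nM, with a range from 600 nM to 5500 nM.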

Compound 3, concentration for 50% growth inhibition: 1090 nM
Beside the measured number, compound 3's estimate is 1.7-fold (0.22 log units) above it; measured number inside the range.
By their numbers in this assay, from the lowest: compounds 3 and 2 (each within the scatter of the next); then compound 1.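

In this assay, the exchange of methoxy for hydroxy on the chlorophenyl arm gives a 1.1-fold lower number from compound 2 to compound 3 (0.05 log units; within the scatter), so with this pair the free hydroxy and its methyl ether cannot be told apart, and the methyl on that oxygen is dispensable for this read-out. A second single-place comparison, trifluoromethyl in place of hydrogen on an aromatic carbon, gives a 6.0-fold lower number from compound 1 to compound 3 (0.78 log units; beyond the scatter), a modest step that lies beyond the scatter and so marks this other place, not the oxygen, as the one that moves the number among the pairs shown. No measurement offered here accounts for either step.

Open, as far as these compounds go, is whether an ethoxy or an amine at the same place would also stay within the scatter. Also open, from the compounds shown here alone, is whether methoxy and hydroxy would still match with hydrogen in place of that trifluoromethyl.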